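A larger alkyl group on the aryl ring of the piperidine

The compounds below may be only part of what the source reports. "The series", "measured", "known", "first", "only" and "open" are said of these compounds alone.

Measured so far:
Compound 1 `COc1ccc(C)c(N2CCC(COc3cccc(C(CC(=O)O)C4CC4)c3)CC2)c1` gives 270 nM in a functional assay on cells for agonist activity at Free fatty acid receptor 1 (Homo sapiens), read by FLIPR and calcium flux, with a stated time of 60 min; a lower number here means that less compound is needed, a higher number that more compound is needed for the effect.
Compound 2 `COc1ccc(C(C)C)c(N2CCC(COc3cccc(C(CC(=O)O)C4CC4)c3)CC2)c1` gives 120 nM in this assay.

Among the measured compounds shown here, of the two measured compounds, compound 2 gives the lower number in this assay, and the single step so far, a 2.3-fold lower number from compound 1 to compound 2 (0.35 log units; beyond the scatter), comes from exchanging a methyl for an isopropyl on an aromatic carbon of the shared core. Compound 3 `COc1ccc(CCC(C)(C)C)c(N2CCC(COc3cccc(C(CC(=O)O)C4CC4)c3)CC2)c1` continues along the same line: 3,3-dimethylbutyl in place of isopropyl on an aromatic carbon. For the measured compounds named here, the only measured step that bears on this change is the one from methyl to isopropyl, which lowered the number modestly but beyond the scatter. Whether a still larger group keeps that trend going cannot be read from two compounds, and the new group is also longer rather than just broader. The expectation, therefore, is a number near that of compound 2, perhaps a little lower, as a 1.2-fold lower number from compound 2 to compound 3 (0.08 log units; within the scatter). Compound 3 is estimated to give 100 nM in this assay, with a plausible range from 30 nM to 400 nM.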

Compound 3, half-maximal effective concentration: 34 nM
Compound 3: the middle estimate sits 2.9-fold (0.47 log units) above what was measured; the range from low to high includes it.
By their numbers in this assay, from the lowest: compound 3; then compound 2; then compound 1.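

The trend seen in the first step carries on past isopropyl: on this aromatic carbon, para to a methoxy group, the 3,3-dimethylbutyl group gives a further drop in this assay (a 3.5-fold lower number from compound 2 to compound 3 (0.55 log units; beyond the scatter)), so isopropyl is not the upper size limit for this position. Taken as a whole, the series of methyl, isopropyl and 3,3-dimethylbutyl shows the number falling with each larger alkyl group, with none of the three compounds going against that order, and the total change is clearer than either single step (a 7.9-fold lower number from compound 1 to compound 3 (0.90 log units; beyond the scatter)). Nothing available here explains why these larger alkyl groups give lower numbers.

The compounds shown do not separate the length of the new group from its branching, and a straight hexyl chain at this position would be needed to tell those two apart. They also leave open how far the trend extends, for example to a still longer chain, or whether a cyclohexyl ring or a chain carrying an ether oxygen or an amine would fit this position equally well.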